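The source may hold more compounds than are shown below. What is called first, only, known or untested is meant among the compounds shown, and "the series" means these compounds.

Series notes. Compound 2 `Cc1ccc(Oc2ccc(CC3SC(=O)NC3=O)cc2)cc1` gives 547 nM in a functional assay for agonist activity at Free fatty acid receptor 1 (Homo sapiens), read by FLIPR, in the presence of a further agent that is not named here (a higher number here means that more compound is needed for the effect, a lower number that less compound is needed), the second highest of the three numbers; compound 1 `Cc1ccc(Oc2ccc(CC3SC(=O)NC3=O)cc2)cc1C` gives 727 nM, and compound 3 `Cc1ccc(Oc2ccc(CC3SC(=O)NC3=O)cc2)c(C)c1` gives 121 nM. The measured steps are a 1.3-fold lower number from compound 1 to compound 2 (0.12 log units; within the scatter) and a 4.5-fold lower number from compound 2 to compound 3 (0.66 log units; beyond the scatter). Compound 4 `O=C1NC(=O)C(Cc2ccc(Oc3ccc(Cl)cn3)cc2)S1` carries 5-chloropyridin-2-yl in place of 4-methylphenyl on an oxygen on an aromatic ring. Both measured steps concern only methyl groups on the same ring; neither exchanges the ring itself or brings in a chlorine or a ring nitrogen. They bear on the present change only loosely and set no clear direction. The expectation for compound 4 is accordingly a step of a 1.1-fold lower number from compound 2 to compound 4 (0.04 log units; within the scatter) that may well stay within the scatter, held with wide uncertainty. The estimate for compound 4 is 500 nM, range 150 nM to 1800 nM.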

Compound 4, half-maximal effective concentration: 1870 nM
Compound 4: middle estimate off by 3.7-fold (0.57 log units), on the low side, and the stated range ends below it.
By their numbers in this assay, from the lowest: compound 3; then compounds 2 and 1 (each within the scatter of the next); then compound 4.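

Exchanging 4-methylphenyl for 5-chloropyridin-2-yl on an oxygen on an aromatic ring gives a 3.4-fold higher number from compound 2 to compound 4 (0.53 log units; beyond the scatter) in this assay. Where the earlier steps touched only methyl groups, this one replaces the ring itself and shows that the number at this position can also rise beyond the scatter. No measured evidence bears on the reason for this step.

Going by these compounds, the ring nitrogen and the chlorine enter together, so their separate shares remain open. A 4-chlorophenyl or an unsubstituted pyridin-2-yl group at this place would separate them.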